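The source may hold more compounds than are shown below. What is called first, only, known or untested is meant among the compounds shown, and "the series" means these compounds.

In a functional assay on T98G cells (Homo sapiens) for inhibition, read by MTT assay, with a stated time of 72 h (on this read-out higher numbers stand for weaker inhibition and lower numbers for stronger inhibition), compound 3 `CCNC(=S)NC1CC(C)(C)Oc2ccc(Cl)cc21` gives only a limit, > 100000 nM, and not a number. Among its neighbours, compound 2 `CC(C)NC(=S)NC1CC(C)(C)Oc2ccc(Cl)cc21` gives 91000 nM, and compound 1 `CC1(C)CC(NC(=S)Nc2ccc(C#N)cc2)c2cc(Cl)ccc2O1`, which carries a 4-cyanophenyl group, gives 10000 nM. Compound 4 `CC1(C)CC(NC(=S)Nc2ccccc2)c2cc(Cl)ccc2O1` has phenyl in place of ethyl on an amide-type nitrogen. Going by the values given here, two measured steps bear on this change: ethyl in place of 4-cyanophenyl gave an at least 10-fold higher number from compound 1 to compound 3 (1.00 log units; beyond the scatter), and isopropyl in its place gave a 9.1-fold higher number from compound 1 to compound 2 (0.96 log units; beyond the scatter). Compound 4 regains an aromatic ring but has no nitrile, so only part of that difference may return. A modest move towards a lower number is expected, estimated as an at least 5.0-fold lower number from compound 3 to compound 4 (0.69 log units; beyond the scatter). Compound 4 is expected at 20000 nM, within an estimated range of 6000 nM to 70000 nM.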

Compound 4, half-maximal inhibitory concentration: 37000 nM
Compound 4: middle estimate off by 1.9-fold (0.27 log units), on the low side, within the range that was stated.
By their numbers in this assay, from the lowest: compound 1; then compound 4; then compound 2. At a limit, above all of these: compound 3.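

In this assay, a phenyl ring without a nitrile already beats both small chains on this nitrogen, giving an at least 2.7-fold lower number from compound 3 to compound 4 (0.43 log units; beyond the scatter) and a 2.5-fold lower number from compound 2 to compound 4 (0.39 log units; beyond the scatter). The nitrile adds to this, as hydrogen in place of cyano gives a 3.7-fold higher number from compound 1 to compound 4 (0.57 log units; beyond the scatter). The first of these steps is only a floor, as compound 3 gives a limit and not a number: the limit of > 100000 nM in this assay, at which 1 of the 4 values shown sits.

On these data alone, whether a non-aromatic cyclohexyl ring would do as well as phenyl stays open. So does whether a methoxy group or a chlorine on the phenyl ring would act as the nitrile does.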